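The source may report more compounds than this note shows. Statements on the series, on what has been measured and on what is new or still open speak of the compounds shown alone.

Within the data shown here, compound 1 `O=C(NO)c1ccc(NCc2nc(-c3cccc4cnccc34)nn2-c2ccccc2)cc1` is one of three compounds measured in an assay on Sf9 cells for inhibition of protein deacetylase HDAC6 (Homo sapiens), read by fluorescence, with a stated time of 40 min, tested at 100 nM; on this read-out lower numbers stand for less inhibition and higher numbers for more inhibition at the one concentration tested (going by the name of the read-out). In that assay compound 1 gives 40.2%. Compound 2 `Cc1cc(C)cc(-n2nc(-c3ccccc3)nc2CNc2ccc(C(=O)NO)cc2)c1` gives 49.8%, and compound 3 `O=C(NO)c1ccc(NCc2nc(-c3ccccc3)nn2-c2ccccc2Cl)cc1` gives 64.6%. Compound 1 thus sits at the low end of the three values: its number and that of compound 2 lie within the scatter of each other, while the gap to compound 3 lies beyond it. Among the measured compounds shown here, the one step between two compounds that differ in a single place runs a number 14.8 percentage points higher from compound 2 to compound 3 (beyond the scatter), where 2-chlorophenyl replaces 3,5-dimethylphenyl on an aromatic nitrogen.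

Compound 4 `Cc1ccc(-c2nc(CNc3ccc(C(=O)NO)cc3)n(-c3ccccc3)n2)o1` is not yet measured. It differs from compound 1 as follows: 5-methylfuran-2-yl in place of isoquinolin-5-yl on an aromatic carbon. For the measured compounds named here, the measured step from compound 2 to compound 3 concerns the group on the aromatic nitrogen, not the group on the aromatic carbon between two ring nitrogen atoms, so no measured step bears directly on this change. Without such a step, the expectation is that the change produces no step beyond the scatter in this assay, with a wide range of uncertainty. The estimated step is a number 0.2 percentage points lower from compound 1 to compound 4 (within the scatter). Compound 4 is therefore expected to give about 40%, between 20% and 62%.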

Compound 4, a percentage reported as inhibition, at one concentration (the size of the read-out at that concentration, not a potency): 60.7%
Beside the measured number, compound 4's estimate is 20.7 percentage points below it; the measured number falls inside the stated range.
By their numbers in this assay, from the lowest: compounds 1 and 2 (each within the scatter of the next); then compounds 4 and 3 (each within the scatter of the next).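

In this assay, among these compounds, the group on the aromatic carbon between two ring nitrogen atoms turns out to shift the read-out, with a number 20.5 percentage points higher from compound 1 to compound 4 (beyond the scatter); until now, the only step beyond the scatter concerned the group on the aromatic nitrogen. The smaller group carries the higher number here: 5-methylfuran-2-yl, with one five-membered aromatic ring, replaces isoquinolin-5-yl, with two six-membered aromatic rings, but this single step cannot separate the loss of a ring from the change of hetero atom from nitrogen to oxygen or the presence of the methyl group. Nothing measured here explains why the number rises with this change.

The compounds shown leave open whether the methyl group matters, which a furan-2-yl without it would test, and how a thiophen-2-yl or a pyridin-3-yl would read at this position. They also leave open whether 5-methylfuran-2-yl on the aromatic carbon and 2-chlorophenyl on the aromatic nitrogen would add up in one compound, and, with a single tested concentration, how the compounds compare in potency.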